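Sulfonyl benzyl change from compound 2 to compound 3

This account rests on a few compounds, and the source may have more. Where it says the series, first, only, none or still open, it means among the compounds named here.

Going by the values given here, in a functional assay (Platelet, plasma) for inhibition, with Homo sapiens as the target (on this read-out lower numbers stand for stronger inhibition and higher numbers for weaker inhibition), compound 1 `N#Cc1cc2c(nc1N1CCC(C(=O)NS(=O)(=O)Cc3cc(Cl)cc(Cl)c3)CC1)COC2=O` gives 30500 nM and compound 2 `N#Cc1ccc(CS(=O)(=O)NC(=O)C2CCN(c3nc4c(cc3C#N)C(=O)OC4)CC2)cc1` gives 8900 nM as the lower of the two numbers so far. Compound 3 `N#Cc1cc2c(nc1N1CCC(C(=O)NS(=O)(=O)Cc3cccc(F)c3)CC1)COC2=O` keeps the shared core and carries 3-fluorophenyl in place of 4-cyanophenyl on a saturated chain carbon bound to a sulfonyl sulfur. Among the compounds with values here, one measured step bears on this place: a 3.4-fold lower number from compound 1 to compound 2 (0.53 log units; beyond the scatter) is modest but beyond the scatter, with 4-cyanophenyl in place of 3,5-dichlorophenyl. Within the data shown here, no measured compound carries 3-fluorophenyl, and a single step sets no trend. With compound 2 at the low end, a modest move toward a higher number is expected in this assay for this change. The estimated step is a 1.6-fold higher number from compound 2 to compound 3 (0.20 log units; within the scatter) on present evidence. For compound 3 the estimated value is 14000 nM with an expected range from 5000 nM to 35000 nM in this read-out.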

Compound 3, half-maximal inhibitory concentration: 70500 nM
The estimate for compound 3 lay 5.0-fold (0.70 log units) below the measured number; the measured number lies above the stated range.
By their numbers in this assay, from the lowest: compound 2; then compound 1; then compound 3.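

In this assay the group on a saturated chain carbon bound to a sulfonyl sulfur now shows a wider spread, with 3-fluorophenyl in place of 4-cyanophenyl giving a 7.9-fold higher number from compound 2 to compound 3 (0.90 log units; beyond the scatter) in this series. The same group in place of 3,5-dichlorophenyl gives a 2.3-fold higher number from compound 1 to compound 3 (0.36 log units; beyond the scatter) as its step, so compound 3 has the highest number of the three and 3,5-dichlorophenyl no longer marks the high end. Nothing in hand explains these differences.

The step between compound 2 and compound 3 changes both the substituent and its ring location, so 4-fluorophenyl and 3-cyanophenyl would be needed to separate the two. Also open, on these data alone, is how this read-out responds to a carboxylic acid or an amine on the phenyl ring, or to a longer chain before it.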